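Cyano for methyl on the benzyl group of compound 3

A few compounds are considered here, and "the series" means these few. Any claim that something is new, unique, unknown or untested is made for them only; others in the source may bear on it.

compound 1 `COc1cc(OC)c(-c2coc3cc(OCc4ccccc4F)ccc3c2=O)cc1OC` gives 1610 nM
compound 2 `COc1cc(OC)c(-c2coc3cc(OCc4ccc(F)cc4)ccc3c2=O)cc1OC` gives 1120 nM
compound 3 `COc1cc(OC)c(-c2coc3cc(OCc4ccccc4C)ccc3c2=O)cc1OC` gives 2150 nM

All three values come from a functional assay on B16 cells (Mus musculus) for antiproliferative activity, read by MTT assay, with a stated time of 24 h (on this read-out higher numbers stand for weaker inhibition and lower numbers for stronger inhibition), and compound 3 is not set apart from the other two. The steps that reach it are a 1.3-fold higher number from compound 1 to compound 3 (0.13 log units; within the scatter) and a 1.9-fold higher number from compound 2 to compound 3 (0.28 log units; within the scatter).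

The next compound is compound 4 `COc1cc(OC)c(-c2coc3cc(OCc4ccccc4C#N)ccc3c2=O)cc1OC`, which has cyano in place of methyl on an aromatic carbon, ortho to a large group, so that 2-methylbenzyl becomes 2-cyanobenzyl (cyano in place of methyl on an aromatic carbon).

Within the data shown here, no measured compound carries cyano, so the evidence is indirect. Among the measured compounds shown here, the closest precedent is a 1.3-fold higher number from compound 1 to compound 3 (0.13 log units; within the scatter), also a swap on an aromatic carbon. Moving the fluoro group gave a 1.4-fold lower number from compound 1 to compound 2 (0.16 log units; within the scatter). Neither step leaves the scatter, so no step beyond the scatter is expected in this assay, and no direction is favoured with any confidence. The expected step is a 1.3-fold lower number from compound 3 to compound 4 (0.10 log units; within the scatter).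

Compound 4 is estimated at 1700 nM, with an expected range of 800 nM to 3600 nM.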

Compound 4, half-maximal inhibitory concentration: 2140 nM
The estimate for compound 4 lay 1.3-fold (0.10 log units) below the measured number; low and high end bracket the measured number.
By their numbers in this assay, from the lowest: compounds 2, 1, 4 and 3 (each within the scatter of the next).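

In this assay cyano in place of methyl on an aromatic carbon, ortho to a large group, gives a 1.0-fold lower number from compound 3 to compound 4 (0.00 log units; within the scatter) and so brings a triple bond and a hydrogen-bond acceptor to this place without a step beyond the scatter. Against the fluoro compounds, cyano in place of fluoro gives a 1.3-fold higher number from compound 1 to compound 4 (0.12 log units; within the scatter) and 2-cyanophenyl in place of 4-fluorophenyl gives a 1.9-fold higher number from compound 2 to compound 4 (0.28 log units; within the scatter) so methyl, fluoro and cyano are not told apart at this place. Nothing shown offers an explanation for this result.

As far as these compounds go, whether any group at this place can move the number beyond the scatter stays open, for example an amine, a carboxylic acid or a longer chain. Also open, from the compounds shown here alone, is where the plain benzyl group, with no added group on its ring, would stand against these four compounds.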